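The source may hold more compounds than are shown below. What is called first, only, known or untested is meant among the compounds shown, and "the series" means these compounds.

Working notes on the series. The shared core carries a triazolylthio or purinylthio naphthol with an amide at the other position; three members have numbers in a functional assay on HCT-116 cells (Homo sapiens) for antiproliferative activity, read by MTT assay, with a stated time of 48 h; on this read-out lower numbers stand for stronger inhibition and higher numbers for weaker inhibition. Compound 1 `O=C(/C=C/c1ccc([N+](=O)[O-])cc1)Nc1cc(Sc2ncn[nH]2)c(O)c2ccccc12` gives only a limit, > 100000 nM, in this assay. Compound 3 `O=C(Nc1cc(Sc2ncnc3nc[nH]c23)c(O)c2ccccc12)c1ccc(Cl)cc1` likewise returns a limit, > 100000 nM, in this assay. For the measured compounds named here, compound 2 `O=C(Nc1cc(Sc2ncn[nH]2)c(O)c2ccccc12)c1cccc([N+](=O)[O-])c1` is the only member with an actual number, 70200 nM in this assay. The other two entries stand at a limit (the limit of > 100000 nM in this assay, at which 2 of the 3 values shown sit). Compound 2 therefore stands alone and cannot be ranked against them beyond the fact that it was readable where they were not.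

Compound 4 `O=C(/C=C/c1ccccc1)Nc1cc(Sc2ncn[nH]2)c(O)c2ccccc12` awaits measurement in this assay. It differs from compound 2 by 2-phenylethenyl in place of 3-nitrophenyl on a carbonyl carbon. Going by the values given here, no measured pair in the set isolates this change, so its size is unknown here; compound 1, which also carries a phenylethenyl amide, sits at the limit, which argues against any gain. The expected step is a 1.3-fold higher number from compound 2 to compound 4 (0.11 log units; within the scatter), a slight weakening that stays within the scatter. Compound 4 is therefore estimated at 90000 nM, with a range from 35000 nM to 250000 nM, and a fair chance that only a limit is reported.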

Compound 4, half-maximal inhibitory concentration: > 100000 nM
Compound 4: only a limit was reported; the forecaster's own chance of this, stated with the estimate: 55%; middle value at least 1.1-fold (0.04 log units) away from the limit.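

At the carbonyl carbon, 2-phenylethenyl in place of 3-nitrophenyl gives in this assay an at least 1.4-fold higher number from compound 2 to compound 4 (0.15 log units; that floor lies within the scatter), so this change shows no gain, and only a floor on its size is available. For the compounds shown here, the step for hydrogen in place of nitro on an aromatic carbon, the one change separating compound 1 and compound 4, cannot be read, as both compounds stand at a limit; the nitro group on the 2-phenylethenyl amide therefore shows no readable effect in either direction. Compound 2 remains the only member with an actual number, and the series now gathers at one ceiling: the limit of > 100000 nM in this assay, at which 3 of the 4 values shown sit.

Going by these compounds, how far beyond the limit compound 4 truly lies stays open, and so does the real size of the change from 3-nitrophenyl to 2-phenylethenyl. Also open, on these data alone, is whether an amine in place of the nitro group of compound 2, or a saturated ethyl chain carrying the phenyl ring in place of the 2-phenylethenyl of compound 4, would give a readable number in this assay.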